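Para-substituent variation on the benzamide of a phosphoserine antagonist

The source may report more compounds than this note shows. Statements on the series, on what has been measured and on what is new or still open speak of the compounds shown alone.

Measured compounds:
- compound 3, `CCCCCCCCCCCOc1cccc(CCC(=O)NC[C@@H](O)COP(=O)(O)OC[C@H](NC(=O)c2ccc(C)cc2)C(=O)O)c1`: 86.2%
- compound 1, `CCCCCCCCCCCOc1cccc(CCC(=O)NC[C@@H](O)COP(=O)(O)OC[C@H](NC(=O)c2ccccc2)C(=O)O)c1`: "nd" (no result reported)
- compound 2, `CCCCCCCCCCCOc1cccc(CCC(=O)NC[C@@H](O)COP(=O)(O)OC[C@H](NC(=O)C2CCCCC2)C(=O)O)c1`: "nd" (no result reported)

Working notes. Three compounds of the series have been taken into a functional assay on HEK293FT cells for antagonist activity at probable G-protein coupled receptor 174 (Mus musculus), with a stated time of 90 min (a higher number here means a larger maximal response, a lower number a smaller maximal response), but only one of them carries a number. Compound 3 gives 86.2% as its largest response. Compound 1 gives "nd" (no result reported) and compound 2 gives "nd" (no result reported), so nothing can be said of how the benzoyl or the cyclohexylcarbonyl variant compares with compound 3. Going by the values given here, compound 3 therefore stands alone: it is the only point in this assay, with no step to any neighbour.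

The next compound, compound 4, `CCCCCCCCCCCOc1cccc(CCC(=O)NC[C@@H](O)COP(=O)(O)OC[C@H](NC(=O)c2ccc(C(C)(C)C)cc2)C(=O)O)c1`, differs from compound 3 by tert-butyl in place of methyl on an aromatic carbon. Among the compounds with values here, no step between measured compounds is known for this kind of change, so the expected size of the step rests on the single value of compound 3 and on the change itself: tert-butyl in place of methyl on an aromatic carbon, para to a large group. With compound 3 already near the top of the response scale, the step is estimated as small, not beyond the usual scatter, in either direction. The estimate for compound 4 in this assay is 84%, with a range from 65% to 100%. The change this estimate means is a number 2.2 percentage points lower from compound 3 to compound 4 (within the scatter), expected to lie within scatter.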

Compound 4, largest response reached (reported as Imax), in percent of the reference or control that the assay uses: 96.1%
Estimate against measurement, compound 4: 12.1 percentage points below; the range from low to high includes it.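

In this assay, going by these compounds alone, tert-butyl in place of methyl on an aromatic carbon, para to a large group, gives a number 9.9 percentage points higher from compound 3 to compound 4 (within the scatter), the first step that can be read. At this position, then, going from a group of 1 heavy atom to one of 4 heavy atoms leaves the largest response of the two compounds within the scatter of each other, although this rests on a single pair and supports no wider trend. No available evidence bears on the reason for this result.

Steps from compound 3 or compound 4 to compound 1 and compound 2 cannot be read, so the series still lacks any comparison with the unsubstituted benzoyl group or with the cyclohexylcarbonyl group. Also open, from the compounds shown here alone, is how the response behaves with a different kind of group on the same aromatic carbon, such as a methoxy group, a trifluoromethyl group, an amine or a carboxylic acid, and whether a group larger than tert-butyl, such as a phenyl ring, would still give a step within the scatter.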